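Moving an Amino Group: A Small Expected Step

The source may report more compounds than this note shows. Statements on the series, on what has been measured and on what is new or still open speak of the compounds shown alone.

In a functional assay on A549 cells (Homo sapiens) for cytotoxicity, read by MTT assay, with a stated time of 72 h (a lower number here means a stronger inhibitor, a higher number a weaker inhibitor), compound 1 `COc1cc(Nc2nc3ccccc3nc2S(=O)(=O)c2ccc(F)cc2)cc(OC)c1` gives 5450 nM and compound 2 `Nc1ccc(Nc2nc3ccccc3nc2S(=O)(=O)c2ccc(F)cc2)cc1` gives 12700 nM, so compound 2 holds the higher of the two numbers and is the weaker inhibitor. Compound 3 `Nc1cccc(Nc2nc3ccccc3nc2S(=O)(=O)c2ccc(F)cc2)c1` has not been measured yet. It keeps the shared core, and one group changes: 3-aminophenyl in place of 4-aminophenyl on a nitrogen on an aromatic ring. The two compounds have the same atoms, joined differently. Within the data shown here, only one measured step bears on this: a 2.3-fold higher number from compound 1 to compound 2 (0.37 log units; beyond the scatter). That modest step replaced 3,5-dimethoxyphenyl with 4-aminophenyl on the same nitrogen, a larger structural change than the one here. Among the measured compounds shown here, no measured pair shows what relocating the amino group does, so a step smaller than that one is expected in this assay, with no firm direction. The expected step is a 1.3-fold lower number from compound 2 to compound 3 (0.10 log units; within the scatter). The estimate for compound 3 is 10000 nM, with an expected range of 4500 nM to 22000 nM.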

Compound 3, half-maximal inhibitory concentration: 6840 nM
Beside the measured number, compound 3's estimate is 1.5-fold (0.16 log units) above it; the range from low to high includes it.
By their numbers in this assay, from the lowest: compounds 1, 3 and 2 (each within the scatter of the next, the first and the last beyond it).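

Moving the amino group, with 3-aminophenyl in place of 4-aminophenyl on the same nitrogen, gives a 1.9-fold lower number from compound 2 to compound 3 (0.27 log units; within the scatter) in this assay, so this relocation gives no difference that can be told from the usual scatter. Replacing 3,5-dimethoxyphenyl with 3-aminophenyl gives a 1.3-fold higher number from compound 1 to compound 3 (0.10 log units; within the scatter), whereas the step from the same starting point to 4-aminophenyl lies beyond the scatter; compounds 1 and 3 therefore cannot be told apart here, although compounds 1 and 2 can. No measurement shown here explains these numbers.

The compounds shown leave open how a different group, such as a carboxylic acid or a nitrile, would read in place of the amino group on this ring. They also leave open whether a single methoxy would read like the 3,5-dimethoxyphenyl of compound 1.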